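Replacing a large side chain with a nitrile on the shared core

A few compounds are considered here, and "the series" means these few. Any claim that something is new, unique, unknown or untested is made for them only; others in the source may bear on it.

In an assay on isolated protein (strain Sprague-Dawley) for inhibition of Amine oxidase [flavin-containing] B (Rattus norvegicus), read by spectrophotometry, with a stated time of 5 min (a higher number here means a weaker inhibitor, a lower number a stronger inhibitor), compound 2 `CCOC(=O)COc1cc(=O)oc2cc(OCc3cccc(Cl)c3)ccc12` gives 1820 nM, the highest number among the three measured compounds. Compound 1 `COc1cc(=O)oc2cc(OCc3cccc(Br)c3)ccc12` gives 5.75 nM, and compound 3 `O=c1cc(CCl)c2ccc(OCc3cccc(Br)c3)cc2o1` gives 209 nM. Within the data shown here, the one step measured at this position of the core, a 36-fold higher number from compound 1 to compound 3 (1.56 log units; beyond the scatter), shows that a change at this spot on the six-membered aromatic ring can move the number a great deal.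

Compound 4 `N#Cc1cc(=O)oc2cc(OCc3cccc(Cl)c3)ccc12` differs from compound 2 as follows: cyano in place of (ethoxycarbonyl)methoxy on an aromatic carbon. Among the measured compounds shown here, no measured pair bears directly on this exchange; the step from compound 1 to compound 3 concerns two other groups at the same place, and compound 1 and compound 3 also carry bromine rather than chlorine on the benzyl ring. What can be taken from the numbers is that the smaller groups, methoxy in compound 1 and chloromethyl in compound 3, both gave lower numbers than the longer chain in compound 2. On that basis the number for compound 4 is expected to fall well below that of compound 2, though the uncertainty is wide.

The estimate for compound 4 is 60 nM, with a range from 10 nM to 400 nM, which is an expected step of a 30-fold lower number from compound 2 to compound 4 (1.48 log units; beyond the scatter).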

Compound 4, half-maximal inhibitory concentration: 102 nM
For compound 4 the middle estimate is 1.7-fold (0.23 log units) below the measured one; low and high end bracket the measured number.
By their numbers in this assay, from the lowest: compound 1; then compound 4; then compound 3; then compound 2.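

In this assay, among these compounds, an 18-fold lower number from compound 2 to compound 4 (1.25 log units; beyond the scatter) is the first step at this place on the shared core measured with chlorine on the benzyl ring, and only this one group changes in it. The earlier step, a 36-fold higher number from compound 1 to compound 3 (1.56 log units; beyond the scatter), ran the other way with bromine on the benzyl ring, so large changes in the number in either direction have now been seen at this position, though in two different benzyl settings. The exchange here swaps (ethoxycarbonyl)methoxy, with 7 heavy atoms and 3 hydrogen-bond acceptors, for cyano, with 2 heavy atoms and 1 hydrogen-bond acceptor, so size, acceptor count and bond type all change at once and this single step cannot separate them.

From the compounds shown here alone, whether an amine, a carboxylic acid or a short alkyl chain at this place would give a number close to that of compound 4 stays open, as does how cyano would fare with bromine in place of chlorine on the benzyl ring. Nothing measured here accounts for the size of this step.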